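The source may report more compounds than this note shows. Statements on the series, on what has been measured and on what is new or still open speak of the compounds shown alone.

Measured compounds in a functional assay on MCF7 cells (Homo sapiens) for antiproliferative activity, read by MTT assay, with a stated time of 72 h; a lower number here means a stronger inhibitor, a higher number a weaker inhibitor:

Compound 1 `CCCSc1nc(N/N=C(\C)c2ccc(OC)cc2)c2nnn(Cc3ccccc3)c2n1` — compound 1 gives > 64000 nM, which is a limit of this assay.
Compound 2 `CCCSc1nc(N/N=C/c2cccs2)c2nnn(Cc3ccccc3)c2n1` — compound 2 gives > 64000 nM, again a limit.
Compound 3 `CCCSc1nc(N/N=C/c2cccc(Cl)c2)c2nnn(Cc3ccccc3)c2n1` — compound 3 gives > 64000 nM, also a limit.

Among the compounds with values here, compound 3 therefore stands at the same place as the two others: no number is known for it, only the limit (the limit of > 64000 nM in this assay, at which 3 of the 3 values shown sit), and the one step that connects two measured compounds, a step that the two limits leave unreadable from compound 2 to compound 3, cannot be read, since both of its ends are limits. Within the data shown here, compound 1 likewise shows only the limit, and no step to it is counted here.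

Compound 4 `CCCSc1nc(N/N=C(\C)c2ccccc2O)c2nnn(Cc3ccccc3)c2n1` differs from compound 3 by a group of 10 heavy atoms (8 carbon, 1 nitrogen, 1 oxygen; one six-membered aromatic ring of carbon only) in place of a group of 9 heavy atoms (7 carbon, 1 nitrogen, 1 chlorine; one six-membered aromatic ring of carbon only), on a nitrogen on an aromatic ring. Among the measured compounds shown here, no measured step bears readably on this change, and the only step that exists is unreadable. There is thus no evidence of any difference beyond the usual scatter in this assay among these compounds, and nothing that would place compound 4 at a measurable number.

Compound 4 is accordingly expected to remain at the limit in this assay, with an estimate of 100000 nM and a range from 50000 nM to 300000 nM. This estimate means a step that the limit leaves unreadable from compound 3 to compound 4, which is expected to be no change that this assay could read.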

Compound 4, half-maximal inhibitory concentration: 11000 nM
Estimate against measurement, compound 4: 9.1-fold (0.96 log units) above; measured number below the stated range.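

In this assay, the group on a carbon with a double bond to nitrogen proves able to move the result off the limit: 2-hydroxyphenyl in place of 4-methoxyphenyl gives an at least 5.8-fold lower number from compound 1 to compound 4 (0.76 log units; beyond the scatter). The wider exchanges of the whole group on a nitrogen on an aromatic ring point the same way, with an at least 5.8-fold lower number from compound 3 to compound 4 (0.76 log units; beyond the scatter) and an at least 5.8-fold lower number from compound 2 to compound 4 (0.76 log units; beyond the scatter), so compound 4 is the only one of the four compounds shown with a measured number. All three steps give only a minimum size and not a full one, since one end of each is a limit: the limit of > 64000 nM in this assay, at which 3 of the 4 values shown sit.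

As far as these compounds go, what 4-hydroxyphenyl or 2-methoxyphenyl would give at this place stays open, so the step to compound 4 cannot yet be divided between the change of the group itself and the change of its position on the phenyl ring. Also open, from the compounds shown here alone, is whether 2-aminophenyl or 2-carboxyphenyl would keep, improve or lose the activity of compound 4, which gives 11000 nM.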